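Replacing 1,3-thiazol-2-yl on a weakly active amide

The source may hold more compounds than are shown below. What is called first, only, known or untested is meant among the compounds shown, and "the series" means these compounds.

In a functional assay on KB cells (Homo sapiens) for antiproliferative activity, read by sulforhodamine B assay, with a stated time of 3 days (on this read-out lower numbers stand for stronger inhibition of growth and higher numbers for weaker inhibition of growth), compound 1 `O=C(Nc1ccccn1)c1cccc(Nc2ncc(F)c(Nc3ccc(F)cc3)n2)c1` gives 20000 nM as its reading. Compound 2 `O=C(Nc1nccs1)c1cccc(Nc2ncc(F)c(Nc3ccc(F)cc3)n2)c1` reads > 10000 nM in the same test, and this is a limit of the assay and not a number. The data therefore contain the limit of > 10000 nM in this assay, at which 1 of the 2 values shown sits, as their only such case. Compound 3 `O=C(Nc1ccc(C(F)(F)F)cc1)c1cccc(Nc2ncc(F)c(Nc3ccc(F)cc3)n2)c1` keeps the shared core but carries 4-(trifluoromethyl)phenyl in place of 1,3-thiazol-2-yl on an amide-type nitrogen, a difference counted as 4-(trifluoromethyl)phenyl in place of 1,3-thiazol-2-yl on an amide-type nitrogen for this swap. One measured step changes the same place, a step that the limit leaves unreadable from compound 1 to compound 2 as it stands, and its size cannot be read, so it points in no direction. Among the measured compounds shown here, the only firm number nearby is that of compound 1 at 20000 nM in a weak range. No shift beyond the usual scatter is therefore expected, and the estimated step is a step that the limit leaves unreadable from compound 2 to compound 3 on that basis. The estimate for compound 3 is 12000 nM with an expected range from 4000 nM to 35000 nM in this assay readings.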

Compound 3, concentration for 50% growth inhibition: > 10000 nM
Compound 3: a limit, no number; the forecaster's own chance of this, stated with the estimate: 50%; the middle value does not contradict the limit.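

The steps from compound 2 to compound 3 and from compound 1 to compound 3 cannot be read, because compound 3, like compound 2, gives a limit of the assay and not a number: the limit of > 10000 nM in this assay, at which 2 of the 3 values shown sit.

The compounds shown leave open whether 4-(trifluoromethyl)phenyl, 1,3-thiazol-2-yl and pyridin-2-yl on the amide-type nitrogen differ at all in this assay.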